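Replacing the cyclohexyl with a butyl chain

This account rests on a few compounds, and the source may have more. Where it says the series, first, only, none or still open, it means among the compounds named here.

Going by the values given here, compound 2 `CC(C)(C)c1ccccc1Oc1ncccc1NC(=O)N[C@H]1CC[C@H](C)CC1` stands at the higher end of the two numbers known here: in a functional assay on cells for antagonist activity at P2Y purinoceptor 1 (Homo sapiens), read by calcium flux (a lower number here means a stronger inhibitor, a higher number a weaker inhibitor), compound 2 gives 7050 nM, whereas compound 1 `CC1CCCCC1NC(=O)Nc1cccnc1Oc1ccccc1C(C)(C)C` gives 820 nM. Among the compounds with values here, the single measured step, an 8.6-fold higher number from compound 1 to compound 2 (0.93 log units; beyond the scatter), is the only guide, and it shows that the shape of the group on the amide-type nitrogen matters for this assay. Compound 3 `CCCCNC(=O)Nc1cccnc1Oc1ccccc1C(C)(C)C` carries butyl in place of 4-methylcyclohexyl on an amide-type nitrogen. Within the data shown here, no measured step covers this change, so the direction can only be guessed; with the ring gone and a shorter chain in its place, a weaker inhibitor than compound 2, or one within the scatter of it, seems more likely than a gain. Compound 3 is therefore expected to give about 10000 nM, with a range from 2500 nM to 40000 nM. The expected step is a 1.4-fold higher number from compound 2 to compound 3 (0.15 log units; within the scatter).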

Compound 3, half-maximal inhibitory concentration: 9980 nM
Estimate against measurement, compound 3: 1.0-fold (0.00 log units) above; the measured number falls inside the stated range.
By their numbers in this assay, from the lowest: compound 1; then compounds 2 and 3 (each within the scatter of the next).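

On the amide-type nitrogen, a ring is not what separates these compounds in this assay: butyl and 4-methylcyclohexyl cannot be told apart, with a 1.4-fold higher number from compound 2 to compound 3 (0.15 log units; within the scatter). The other comparison, a 12-fold higher number from compound 1 to compound 3 (1.09 log units; beyond the scatter), sets 2-methylcyclohexyl apart from butyl, so among the three groups only 2-methylcyclohexyl gives the lower number, and compound 2 shows that a methyl-bearing cyclohexyl ring alone does not guarantee it. Nothing given here explains why these groups differ.

The compounds shown leave open how a plain cyclohexyl, a 2-ethylcyclohexyl or a hexyl chain on this nitrogen would stand in this assay. They also leave open whether a phenyl group there would follow 2-methylcyclohexyl or fall with butyl and 4-methylcyclohexyl.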